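The source may report more compounds than this note shows. Statements on the series, on what has been measured and on what is new or still open speak of the compounds shown alone.

Working notes on the series in a functional assay on the whole organism with Rattus norvegicus as the target; on this read-out higher numbers stand for an effect only at larger amounts of compound and lower numbers for an effect already at smaller amounts.

Within the data shown here, compound 1 `CCc1c(OC)nc2nc(-c3nnc(-c4ccccc4)o3)cn2c1C` is the first member of the shared core. In this assay compound 1 gives > 50 mg/kg, which is a limit of the assay and not a number. Compound 2 `CCc1c(OC)nc2nc(-c3nc(C)cs3)cn2c1C` carries a methoxy on the core and a 4-methyl-1,3-thiazol-2-yl group. In this assay compound 2 gives > 50 mg/kg, again a limit rather than a number. Compound 3 `CCc1c(SC)nc2nc(-c3nc(C)cs3)cn2c1C` is the methylsulfanyl counterpart of compound 2. In this assay compound 3 gives > 50 mg/kg, also a limit. Among the measured compounds shown here, compound 2 therefore stands only at a limit, and the two other values so far are limits as well; all three sit together at the limit of > 50 mg/kg in this assay, at which 3 of the 3 values shown sit.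

For the measured compounds named here, the one step that can be written, a step that the two limits leave unreadable from compound 2 to compound 3, is unreadable in size, so no measured step on this core yet carries a direction. Compound 4 `CCc1csc(-c2cn3c(C)c(CC)c(OC)nc3n2)n1` differs from compound 2 by methyl in place of hydrogen on a saturated chain carbon bound to an aromatic carbon. Going by the values given here, no measured step bears on that change, and the only recorded step is unreadable, so no size or direction beyond the scatter can be expected from it. Compound 4 is estimated at 60 mg/kg, within 20 mg/kg to 200 mg/kg, most likely again a limit. The step from compound 2 to compound 4 is accordingly expected to be a step that the limit leaves unreadable from compound 2 to compound 4.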

Compound 4, minimum effective dose: 50 mg/kg
Compound 4: the middle estimate sits 1.2-fold (0.08 log units) above what was measured, within the range that was stated.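

In this assay, among these compounds, compound 4 gives 50 mg/kg, the first value that is a number and not a limit. Among the compounds shown here, the change of 4-methyl-1,3-thiazol-2-yl to 4-ethyl-1,3-thiazol-2-yl gives a number no higher from compound 2 to compound 4 (the limit leaves the size open), which makes methyl in place of hydrogen on a saturated chain carbon bound to an aromatic carbon the first change on the shared core with a readable direction, though still without a readable size. That direction rests on a single pair, and the rest of the series offers no number to set it against: the limit of > 50 mg/kg in this assay, at which 3 of the 4 values shown sit.

From the compounds shown here alone, whether a longer chain such as propyl, or a polar group such as a primary amine, in place of the ethyl of the 4-ethyl-1,3-thiazol-2-yl group would move the minimum effective dose further remains open. Also open, going by these compounds, is whether the same methyl for hydrogen change would give a number on the methylsulfanyl core of compound 3, so the step cannot yet be said to hold beyond the methoxy core of compound 2.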